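The source may hold more compounds than are shown below. What is called first, only, known or untested is meant among the compounds shown, and "the series" means these compounds.

Measured compounds:
- compound 1 `OC[C@@H]1C[C@H](CO)[C@@H]2C(c3ccc(Cl)cc3)=NO[C@H]12`: in a functional assay on A549 cells (Homo sapiens) for cytotoxicity, read by MTT assay, with a stated time of 48 h (on this read-out lower numbers stand for stronger inhibition and higher numbers for weaker inhibition), compound 1 gives > 50 ug/mL, which is a limit of the assay and not a number.
- compound 2 `OC[C@@H]1C[C@H](CO)[C@@H]2C(c3ccc(F)cc3)=NO[C@H]12`: in this assay compound 2 gives 31.1 ug/mL.

Compound 2 holds the only number shown; the one further value is a limit. For the measured compounds named here, the single measured step, an at least 1.6-fold lower number from compound 1 to compound 2 (0.20 log units; that floor lies within the scatter), has a floor that lies within the scatter, and its starting point is the limit of > 50 ug/mL in this assay, at which 1 of the 2 values shown sits, so it says little about how a change on this aromatic carbon moves the number.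

Compound 3 `COc1ccc(C2=NO[C@@H]3[C@H](CO)C[C@H](CO)[C@H]23)cc1` differs from compound 2 by methoxy in place of fluoro on an aromatic carbon. Going by the values given here, no measured step involves methoxy, and the one step on this ring carbon is small, so in this assay no movement beyond the scatter is expected, and the step of a 1.0-fold lower number from compound 2 to compound 3 (0.02 log units; within the scatter) is estimated accordingly. Compound 3 is expected near 30 ug/mL, between 12 ug/mL and 75 ug/mL, with a fair chance that only a limit is reported.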

Compound 3, half-maximal inhibitory concentration: 36.6 ug/mL
Estimate against measurement, compound 3: 1.2-fold (0.09 log units) below, within the range that was stated.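

Compound 3 gives this aromatic carbon a second number, so a change there can now be read between two real values in this assay, and the step is a 1.2-fold higher number from compound 2 to compound 3 (0.07 log units; within the scatter). Within these two compounds, the larger methoxy group, which also adds a hydrogen-bond acceptor, therefore leaves the read-out about where fluoro has it. Compound 1 remains a limit and not a number, and an at least 1.3-fold lower number from compound 1 to compound 3 (0.13 log units; that floor lies within the scatter) gives only a floor for methoxy in place of chloro, so chloro cannot be placed against the other two groups: the limit of > 50 ug/mL in this assay, at which 1 of the 3 values shown sits.

Going by these compounds, whether any group on this carbon moves the number beyond the scatter remains open, with an amine, a carboxylic acid or a nitrile as untested cases in this set. On these data alone, how far changes elsewhere on the shared core would move the number also remains open.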